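The source may report more compounds than this note shows. Statements on the series, on what has been measured and on what is new or still open speak of the compounds shown alone.

Measured in a functional assay on the whole organism for antagonist activity, with Mus musculus as the target; on this read-out lower numbers stand for an effect already at smaller amounts and higher numbers for an effect only at larger amounts of compound:
- compound 1 `Cn1c(-c2cccc(F)c2)nnc1S(C)(=O)=O`: > 200 mg/kg (a limit)
- compound 2 `Cn1c(-c2ccccc2)nnc1S(C)(=O)=O`: 55 mg/kg
- compound 3 `CSc1nnc(-c2cccc3ccccc23)n1C`: > 200 mg/kg (a limit)

Compound 3 gives > 200 mg/kg, which is a limit and not a number. Among the measured compounds shown here, the series so far is weighted towards (the limit of > 200 mg/kg in this assay, at which 2 of the 3 values shown sit).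

Compound 4 `Cn1c(-c2cccc3ccccc23)nnc1[S+](C)[O-]` keeps the core of compound 3 and changes one group, on an aromatic carbon of a five-membered aromatic ring with 3 nitrogen: a group of 3 heavy atoms (1 carbon, 1 oxygen, 1 sulfur; no ring) in place of a group of 2 heavy atoms (1 carbon, 1 sulfur; no ring), on an aromatic carbon. The methylsulfanyl group leaves, and a group of 3 heavy atoms enters.

For the measured compounds named here, no measured step changes the group at this place. Going by the values given here, the only measured step is an at least 3.6-fold lower number from compound 1 to compound 2 (0.56 log units; beyond the scatter). It puts hydrogen in place of fluoro on an aromatic carbon at a different place, so it bears on this change only indirectly: a single change can take a compound off the limit in this assay.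

Among the compounds with values here, compound 2 gives 55 mg/kg, the only number so far. A modest step towards a lower number is therefore expected in this assay, although a result that stays at the limit remains quite possible. The expected step is an at least 1.6-fold lower number from compound 3 to compound 4 (0.22 log units; that floor lies within the scatter). For compound 4 the estimated value is 120 mg/kg, with an expected range from 40 mg/kg to 300 mg/kg.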

Compound 4, dose for half-maximal effect: > 200 mg/kg
Compound 4: a limit, no number (the forecaster's own chance of this, stated with the estimate: 45%); middle value at least 1.6-fold (0.22 log units) from the limit.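

In this assay compound 3 gives > 200 mg/kg, a limit. Compound 4 gives > 200 mg/kg, also a limit, and no step can be read between these two compounds. The compounds shown leave open how the group on this aromatic carbon bears on the read-out in this assay, and whether any group here gives a number rather than a limit.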